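A few compounds are considered here, and "the series" means these few. Any claim that something is new, unique, unknown or untested is made for them only; others in the source may bear on it.

Compounds measured so far:
- compound 1 `CCCCc1ccc(CNC(C)=O)c(=O)n1Cc1ccc(-c2ccccc2-c2nn[nH]n2)cc1`: 3 nM
- compound 2 `CCCCc1ccc(CNS(=O)(=O)c2ccccc2)c(=O)n1Cc1ccc(-c2ccccc2-c2nn[nH]n2)cc1`: 7 nM

In a functional assay (aorta) for antagonist activity, with Oryctolagus cuniculus as the target (on this read-out higher numbers stand for weaker inhibition and lower numbers for stronger inhibition), compound 1 gives 3 nM and compound 2 gives 7 nM. Among the measured compounds shown here, compound 2 stands with the highest number of the two; the only step measured so far is a 2.3-fold higher number from compound 1 to compound 2 (0.37 log units; beyond the scatter), a modest rise beyond the scatter.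

Compound 3 `CCCCc1ccc(CNS(=O)(=O)c2ccc(C)cc2)c(=O)n1Cc1ccc(-c2ccccc2-c2nn[nH]n2)cc1` is not yet measured. It differs from compound 2 by methyl in place of hydrogen on an aromatic carbon. For the measured compounds named here, no measured step in this set exchanges hydrogen for methyl on an aromatic carbon; the one measured step concerns the exchange of acetyl for phenylsulfonyl on the amine nitrogen and does not bear directly on this change. With nothing in the data pointing either way, the expectation for compound 3 is a number close to that of compound 2, with a step of a 1.1-fold higher number from compound 2 to compound 3 (0.06 log units; within the scatter) that is expected to stay within the usual scatter. Compound 3 is therefore estimated at 8 nM in this assay, in the range 3 nM to 25 nM.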

Compound 3, half-maximal inhibitory concentration: 9 nM
Estimate against measurement, compound 3: 1.1-fold (0.05 log units) below; low and high end bracket the measured number.
By their numbers in this assay, from the lowest: compound 1; then compounds 2 and 3 (each within the scatter of the next).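

In this assay, among the compounds shown here, the first change on the aromatic ring of the sulfonyl group, methyl in place of hydrogen para to a large group, gives a 1.3-fold higher number from compound 2 to compound 3 (0.11 log units; within the scatter), so this place accepts a methyl without a readable shift in the number. The comparison with the acetyl compound holds with the added methyl: (4-methylphenyl)sulfonyl in place of acetyl gives a 3.0-fold higher number from compound 1 to compound 3 (0.48 log units; beyond the scatter), a modest step of the same direction as a 2.3-fold higher number from compound 1 to compound 2 (0.37 log units; beyond the scatter), and both sulfonyl compounds sit above compound 1 beyond the scatter. Nothing at hand gives a reason for either step or for the absence of a readable methyl effect.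

Going by these compounds, whether this place stays as permissive for a group other than methyl remains open: a methoxy, a carboxylic acid or an amine there could still move the number beyond the scatter. On these data alone, it is also open whether the step away from acetyl belongs to the sulfonyl link or to the aromatic ring it carries, a question that a methylsulfonyl group on the same amine nitrogen would separate.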